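The source may hold more compounds than are shown below. What is called first, only, known or untested is meant among the compounds shown, and "the series" means these compounds.

Measured in an ADME assay (liver, Mus musculus) for metabolic stability, using microsomes; a higher number here means that the compound lasts longer, a lower number that the compound disappears faster:
Compound 1 `C=CC(=O)Nc1cccc(CNc2nc(Nc3cc(F)c(N4CCN(C(C)=O)CC4)c(F)c3)ncc2Cl)c1`: 0.0567 h
Compound 2 `C=CC(=O)Nc1cccc(CNc2nc(Nc3cnn(C4CCOCC4)c3)ncc2Cl)c1`: 0.025 h

Compound 2 holds the lower of the two numbers at 0.025 h, while compound 1 stands higher at 0.0567 h, a gap beyond the usual scatter. Compound 3 `C=CC(=O)Nc1cccc(CNc2nc(Nc3cnn(CC(=O)N4CCOCC4)c3)ncc2Cl)c1` differs from compound 2 by ((morpholin-4-yl)carbonyl)methyl in place of oxan-4-yl on an aromatic nitrogen. Among the compounds with values here, no measured pair shows this change, so the expectation is loose. In this assay, no shift beyond the scatter is expected, and no firm direction. The estimated step is a 1.2-fold higher number from compound 2 to compound 3 (0.08 log units; within the scatter). For compound 3 the estimated half-life is 0.03 h, with a range of 0.012 h to 0.07 h.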

Compound 3, half-life: 0.12 h
The estimate for compound 3 lay 4.0-fold (0.60 log units) below the measured number, outside the stated range (above it).
By their numbers in this assay, from the lowest: compound 2; then compound 1; then compound 3.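

Within the data shown here, on the aromatic nitrogen of the five-membered aromatic ring, the group proves able to shift the read-out in this assay: ((morpholin-4-yl)carbonyl)methyl in place of oxan-4-yl gives a 4.8-fold higher number from compound 2 to compound 3 (0.68 log units; beyond the scatter) and is the first change in one place alone. Compounds 1 and 2 differ in more than one place and could not show this. Nothing at hand accounts for the step. The compounds shown leave open whether the carbonyl or the morpholine ring carries the step, and whether a carboxylic acid or a piperidine amide on the same nitrogen would behave alike.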